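A Cyclopentyl Swap at the Assay Limit

A few compounds are considered here, and "the series" means these few. Any claim that something is new, unique, unknown or untested is made for them only; others in the source may bear on it.

Two related compounds have been tested so far in a functional assay on NCI-H23 cells (Homo sapiens) for antiproliferative activity, read by sulforhodamine B assay (a higher number here means a weaker inhibitor of growth, a lower number a stronger inhibitor of growth), and neither has yet given a number. Compound 1 (`COc1cccc(OCCC(C)(C)C)c1C(=O)/C=C/c1ccc(O)cc1`) reads > 30000 nM here, which is a limit of the assay and not a number. Compound 2 (`CC(C)=CCOc1cccc(O)c1C(=O)/C=C/c1ccc(O)cc1`) reads > 30000 nM here, which is likewise a limit and not a number. Compound 2 therefore has no position of its own, and the whole record so far is the limit of > 30000 nM in this assay, at which 2 of the 2 values shown sit, with no measured value to set against it. Compound 3 (`O=C(/C=C/c1ccc(O)cc1)c1c(O)cccc1OCC1CCCC1`) keeps the core of compound 2 and alters only the side chain, as cyclopentyl in place of 2-methylprop-1-en-1-yl on a saturated chain carbon bound to an oxygen on an aromatic ring shows: cyclopentyl in place of 2-methylprop-1-en-1-yl, which turns 3-methylbut-2-en-1-yl into cyclopentylmethyl. Among the measured compounds shown here, no measured step speaks to this change, so the limit of compound 2 is the only anchor. The expected step of an at least 1.3-fold lower number from compound 2 to compound 3 (0.13 log units; that floor lies within the scatter) in this assay is estimated to stay within the usual scatter, with no firm direction. Compound 3 is expected to give about 22000 nM as its value, with an estimated range from 8000 nM to 30000 nM in all likelihood.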

Compound 3, concentration for 50% growth inhibition: 3160 nM
Beside the measured number, compound 3's estimate is 7.0-fold (0.84 log units) above it; measured number outside the range, below it.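

In this assay compound 3 is the first compound shown to give a number and not a limit, so this side chain is a place where a single change can bring the read-out clear of the limit. Turning 3-methylbut-2-en-1-yl into cyclopentylmethyl, with the shared core held fixed, gives an at least 9.4-fold lower number from compound 2 to compound 3 (0.97 log units; beyond the scatter), a change that lies beyond the usual scatter. The size of that step is only a floor, since compound 2 holds a limit and not a number: the limit of > 30000 nM in this assay, at which 2 of the 3 values shown sit.

The compounds shown leave open whether the gain goes with the five-membered ring itself or with the loss of the double bond outside aromatic rings, as this one change brings both at once, and an open saturated chain such as 3-methylbutyl in the same place would tell these two apart. Also open, as far as these compounds go, is whether the ring size matters, which a cyclobutylmethyl or a cyclohexylmethyl group would test, and how far the number can fall from that of compound 3.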